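Trimming the sulfonyl alkyl group: from isobutyl to methyl

This account rests on a few compounds, and the source may have more. Where it says the series, first, only, none or still open, it means among the compounds named here.

Measured compounds:
compound 1, `Cc1ccc(S(=O)(=O)Cc2ccccc2)cc1C#Cc1cc(Cl)ccc1OCC(=O)O`, 5 nM
compound 2, `CS(=O)(=O)c1cccc(C#Cc2cc(Cl)ccc2OCC(=O)O)c1`, 15 nM
compound 3, `Cc1ccc(S(=O)(=O)CC(C)C)cc1C#Cc1cc(Cl)ccc1OCC(=O)O`, 3 nM

In an assay on CHO cells for displacement of a labelled ligand from prostaglandin D2 receptor 2 (Homo sapiens), read by scintillation counting (a higher number here means a weaker inhibitor, a lower number a stronger inhibitor), compound 3 gives 3 nM, the lowest of the three numbers. Compound 1 is its nearest neighbour, a 1.7-fold lower number from compound 1 to compound 3 (0.22 log units; within the scatter), a step that stays within the scatter. Compound 2 lies furthest away, giving 15 nM in this assay.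

The unmeasured compound 4, `Cc1ccc(S(C)(=O)=O)cc1C#Cc1cc(Cl)ccc1OCC(=O)O`, differs from compound 3 by hydrogen in place of isopropyl on a saturated chain carbon bound to a sulfonyl sulfur. Going by the values given here, the only measured step at this position, a 1.7-fold lower number from compound 1 to compound 3 (0.22 log units; within the scatter), swaps one large group for another and changes little; it does not show how removal of the whole isopropyl portion behaves. Compound 2 also carries a methylsulfonyl group, but it differs from compound 4 elsewhere as well, so its value can only hint that a methylsulfonyl compound can still give a low number here.

Compound 4 is therefore expected to remain close to compound 3, with a 2.3-fold higher number from compound 3 to compound 4 (0.37 log units; beyond the scatter) as the estimated step, a modest rise. The estimate for compound 4 in this assay is 7 nM, with a range from 3 nM to 20 nM.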

Compound 4, inhibition constant: 5 nM
Compound 4: the middle estimate sits 1.4-fold (0.15 log units) above what was measured, and the stated range covers the measured number.
By their numbers in this assay, from the lowest: compounds 3, 1 and 4 (each within the scatter of the next); then compound 2.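

In this assay, cutting isobutylsulfonyl back to methylsulfonyl gives a 1.7-fold higher number from compound 3 to compound 4 (0.22 log units; within the scatter), so the whole isopropyl portion on the saturated chain carbon bound to the sulfonyl sulfur can be replaced by hydrogen without a step beyond the scatter. Replacing the phenyl at that same carbon by hydrogen gives no change at the digits printed from compound 1 to compound 4 (within the scatter), so compounds 1, 3 and 4 stand within the scatter of one another despite the very different groups they carry there. The step that does pass beyond the scatter lies elsewhere: methyl in place of hydrogen on an aromatic carbon gives a 3.0-fold lower number from compound 2 to compound 4 (0.48 log units; beyond the scatter), which makes this methyl, and not the group on the sulfonyl, the one single change shown here that moves the number beyond the scatter.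

Nothing available explains why the sulfonyl position accepts these changes or why the aromatic methyl counts. As far as these compounds go, it remains open whether an amine, a hydroxyl or a carboxylic acid on the carbon bound to the sulfonyl sulfur would stay as close as these three compounds, and whether the aromatic methyl step would be the same size with an isobutylsulfonyl group in place.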